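The compounds below may be only part of what the source reports. "The series", "measured", "known", "first", "only" and "open" are said of these compounds alone.

Series so far, in an ADME assay on MOLT-3 cells (Homo sapiens) for cytotoxicity, with a stated time of 7 days; a lower number here means that less compound is tolerated, a higher number that more compound is tolerated:
- compound 1 `Nc1nc(OCC(F)(F)F)c2ncn(/C=C3/CC3(CO)CO)c2n1`: > 20000 nM (a limit, not a number)
- compound 2 `Nc1nc(N2CCCC2)c2ncn(/C=C3/CC3(CO)CO)c2n1`: "not determined" (no result reported)
- compound 3 `Nc1nc(NC2CCCCC2)c2ncn(/C=C3/CC3(CO)CO)c2n1`: "not determined" (no result reported)

Compound 3 has no single number in this assay, so it gives no fixed point from which to measure. Compound 2 is in the same position. Within the data shown here, the only reading of any kind is the limit of > 20000 nM in this assay, at which 1 of the 3 values shown sits. That reading is a limit, so it gives no exact value either.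

Compound 4 `CCCCCOc1nc(N)nc2c1ncn2/C=C1/CC1(CO)CO` is still to be measured. It carries pentyloxy in place of cyclohexylamino on an aromatic carbon of the shared core: pentyloxy in place of cyclohexylamino on an aromatic carbon. Among the measured compounds shown here, no measured step involves a change at this carbon, so no step size can be taken from the data. The expectation therefore rests on compound 1 alone, with its limit of > 20000 nM. Compound 4 is expected to stay close to that region in this assay, with no shift clearly beyond the scatter and only a slight lean toward a lower number. A report of a limit rather than a number is a real possibility.

The estimated value for compound 4 is 18000 nM, with an expected range of 5000 nM to 50000 nM.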

Compound 4, half-maximal cytotoxic concentration: > 20000 nM
Compound 4: no number, only a limit; the forecaster's own chance of this, stated with the estimate: 60%; middle value at least 1.1-fold (0.04 log units) away from the limit.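

In this assay, among these compounds, no step from compound 1 to compound 4 can be read, because both compounds stand at a limit: the limit of > 20000 nM in this assay, at which 2 of the 4 values shown sit. The compounds shown leave open where the half-maximal cytotoxic concentration of any of them actually lies, and whether butyl in place of trifluoromethyl changes it at all.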